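Swapping bromophenyl for methylphenyl on the ketone carbon

The source may report more compounds than this note shows. Statements on the series, on what has been measured and on what is new or still open speak of the compounds shown alone.

Two members of one series have been measured in a functional assay on Ehrlich cells (Mus musculus) for cytotoxicity, read by MTT assay, with a stated time of 48 h; on this read-out lower numbers stand for stronger inhibition and higher numbers for weaker inhibition. Compound 1 `Cc1ccc(C(=O)c2ccc(OCC(=O)Nc3nc(-c4ccccc4)cs3)c(C)c2)cc1` gives 29900 nM in this assay. Compound 2 `Cc1cc(C(=O)c2cccc(Br)c2)ccc1OCC(=O)Nc1nc(-c2ccccc2)cs1` gives 24400 nM in this assay, which sits at one end of the two numbers, but its gap to compound 1 is within the scatter. Among the measured compounds shown here, the single measured step, a 1.2-fold lower number from compound 1 to compound 2 (0.09 log units; within the scatter), therefore shows no real movement. Compound 3 `Cc1cc(C(=O)c2ccccc2C)ccc1OCC(=O)Nc1nc(-c2ccccc2)cs1` is not yet measured; it differs from compound 2 by 2-methylphenyl in place of 3-bromophenyl on a carbonyl carbon. For the measured compounds named here, only that one step speaks to this kind of swap on the carbonyl carbon, and it was small, so the numbers give no direction to lean on. The step from compound 2 to compound 3 is expected to stay within the scatter, a 1.1-fold higher number from compound 2 to compound 3 (0.04 log units; within the scatter), because the earlier step of a 1.2-fold lower number from compound 1 to compound 2 (0.09 log units; within the scatter) was itself within it. Compound 3 is estimated to give 27000 nM, with a range from 12000 nM to 60000 nM.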

Compound 3, half-maximal inhibitory concentration: 25800 nM
The estimate for compound 3 lay 1.0-fold (0.02 log units) above the measured number, within the range that was stated.
By their numbers in this assay, from the lowest: compounds 2, 3 and 1 (each within the scatter of the next).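

In this assay, 2-methylphenyl in place of 3-bromophenyl on the carbonyl carbon gives a 1.1-fold higher number from compound 2 to compound 3 (0.02 log units; within the scatter), and 2-methylphenyl in place of 4-methylphenyl gives a 1.2-fold lower number from compound 1 to compound 3 (0.06 log units; within the scatter). This position now has three substituted phenyl groups to compare, and none separates from the others, whether the ring carries bromine or a methyl group, and whether the methyl group is in the 2-methylphenyl or the 4-methylphenyl arrangement. No other measurement is available to explain why these numbers match.

On these data alone, whether any group on this carbonyl carbon can shift the number remains open, and a phenyl ring bearing an amine or a carboxylic acid, or a longer alkyl chain in place of the ring, would test this. As far as these compounds go, it also remains open whether changes elsewhere on the shared core would behave in the same way.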